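The source may report more compounds than this note shows. Statements on the series, on what has been measured and on what is new or still open speak of the compounds shown alone.

In a functional assay on ECa-109 cells (Homo sapiens) for inhibition, read by MTT assay, with a stated time of 72 h (on this read-out higher numbers stand for weaker inhibition and lower numbers for stronger inhibition), compound 2 `CC(C)c1ccc(-c2nc(SCc3cn(CC(=O)NC(=O)Nc4ccccn4)nn3)nc(Nc3cccc(Cl)c3)c2C#N)cc1` gives 13300 nM, the second highest of three numbers. Compound 1 `CC(C)c1ccc(-c2nc(SCc3cn(CC(=O)NC(=O)Nc4ccccn4)nn3)nc(Nc3ccc(Cl)cc3)c2C#N)cc1` gives 11200 nM, with a 1.2-fold higher number from compound 1 to compound 2 (0.07 log units; within the scatter); compound 3 `CC(C)c1ccc(-c2nc(SCc3cn(CC(=O)NC(=O)Nc4ccccn4)nn3)nc(Nc3cccc([N+](=O)[O-])c3)c2C#N)cc1` gives 31300 nM, with a 2.4-fold higher number from compound 2 to compound 3 (0.37 log units; beyond the scatter). Compound 4 `CC(C)c1ccc(-c2nc(SCc3cn(CC(=O)NC(=O)Nc4ccccn4)nn3)nc(Nc3ccccc3F)c2C#N)cc1` has yet to be measured in this assay. The change from compound 2 is 2-fluorophenyl in place of 3-chlorophenyl on a nitrogen on an aromatic ring. Of the measured steps, only the move of the chloro substituent bears on this change, and it is small, so a shift within the scatter is expected for compound 4, with a 1.1-fold lower number from compound 2 to compound 4 (0.03 log units; within the scatter). The estimate for compound 4 in this assay is 12500 nM, within a range from 5000 nM to 32000 nM, because compound 2 gives 13300 nM.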

Compound 4, half-maximal inhibitory concentration: 15500 nM
For compound 4 the middle estimate is 1.2-fold (0.09 log units) below the measured one, within the range that was stated.
By their numbers in this assay, from the lowest: compounds 1, 2 and 4 (each within the scatter of the next); then compound 3.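

In this assay, 2-fluorophenyl on this nitrogen stays within the scatter of both chlorophenyl groups (a 1.2-fold higher number from compound 2 to compound 4 (0.07 log units; within the scatter) and a 1.4-fold higher number from compound 1 to compound 4 (0.14 log units; within the scatter)), so a fluoro substituent fits the same group of values as a chloro substituent at this place. Going by these compounds alone, compound 3, with 3-nitrophenyl, remains the one compound set apart (a 2.0-fold lower number from compound 3 to compound 4 (0.31 log units; beyond the scatter)). No measurement shown accounts for this separation. The compounds shown leave open how plain phenyl, or a phenyl carrying an amine or a carboxylic acid, would compare with these four.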